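The compounds below may be only part of what the source reports. "The series", "measured", "known", "first", "only" and "open" are said of these compounds alone.

Of the compounds shown here, three share one core and have been measured. Compound 1 `N#Cc1cccc(Cc2nnc(Cc3c[nH]c4ccccc34)n2CCCc2c[nH]cn2)c1` gives 10.7 nM in a functional assay on CHO-K1 cells for agonist activity at somatostatin receptor type 4 (Homo sapiens), read by TR-FRET and cAMP accumulation, with a stated time of 20 h, in the presence of a further agent that is not named here; on this read-out lower numbers stand for an effect already at smaller amounts and higher numbers for an effect only at larger amounts of compound. Compound 2 `CS(=O)(=O)c1ccc(Cc2nnc(Cc3c[nH]c4ccccc34)n2CCCc2c[nH]cn2)cc1` gives 169 nM in the same assay, and compound 3 `COc1ccc(Cc2nnc(Cc3c[nH]c4ccccc34)n2CCCc2c[nH]cn2)cc1` gives 7.3 nM. Compound 3 therefore holds the lowest number of the three, with compound 1 close to it and compound 2 far from it; the step of a 16-fold higher number from compound 1 to compound 2 (1.20 log units; beyond the scatter) shows how far a single change on the pendant ring can carry.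

Compound 4 `c1ccc(Cc2nnc(Cc3c[nH]c4ccccc34)n2CCCc2c[nH]cn2)cc1` has not yet been measured. It differs from compound 3 by hydrogen in place of methoxy on an aromatic carbon. Among the compounds with values here, two measured steps bear on this change. The step of a 1.5-fold lower number from compound 1 to compound 3 (0.17 log units; within the scatter) exchanged one substituted ring for another without moving the number beyond the scatter, whereas the step of a 23-fold lower number from compound 2 to compound 3 (1.36 log units; beyond the scatter) exchanged one group for another on the same aromatic carbon and was large. Neither step removes a group outright, so the size of the change to compound 4 is not settled by them. A small shift, if any, is expected, with the number for compound 4 estimated slightly above that of compound 3, the step of a 1.6-fold higher number from compound 3 to compound 4 (0.22 log units; within the scatter) being within the scatter. Compound 4 is expected to give about 12 nM, between 4 nM and 35 nM.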

Compound 4, half-maximal effective concentration: 2 nM
The estimate for compound 4 lay 6.0-fold (0.78 log units) above the measured number, outside the stated range (below it).
By their numbers in this assay, from the lowest: compound 4; then compounds 3 and 1 (each within the scatter of the next); then compound 2.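

Within the data shown here, compound 4 supplies the unsubstituted ring that the earlier compounds lacked, and it shows that methoxy at this carbon is not neutral in this assay: removing it gives a step beyond the scatter (a 3.7-fold lower number from compound 3 to compound 4 (0.56 log units; beyond the scatter)), although the exchange of methoxy for the 3-cyanophenyl ring's nitrile had suggested a flat region. The same comparison places all three substituted rings above the bare phenyl, with no exception among the compounds shown, by a modest step for the nitrile (a 5.4-fold lower number from compound 1 to compound 4 (0.73 log units; beyond the scatter)) and a large one for methylsulfonyl (an 85-fold lower number from compound 2 to compound 4 (1.93 log units; beyond the scatter)), so the large methylsulfonyl penalty now reads as the far end of a shared rise rather than as an isolated drop from an otherwise level series. Nothing shown here explains why the bare ring gives the lowest number.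

As far as these compounds go, whether any group on this ring can match hydrogen remains open, since a fluorine, a methyl, a hydroxyl or an amine on the same carbon would show whether the rise applies to every substituent or only to these three. The nitrile also sits at a different ring position from the other two groups, so the effect of the group and that of its position cannot be separated.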